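Notes on compound 3: methyl on the chain carbon

A few compounds are considered here, and "the series" means these few. Any claim that something is new, unique, unknown or untested is made for them only; others in the source may bear on it.

Compound 1 `C[C@@H](CNc1ccc(OC(F)(F)F)cc1)NC(=O)[C@H](CC1CCCCC1)NC(=O)OC1CCOCC1` and compound 2 `C[C@@H](CNc1ccc(OC(F)(F)F)cc1)NC(=O)[C@H](CC1CCCCC1)NC(=O)N1CCOCC1` share one core and differ only at the carbonyl carbon. In an assay on isolated protein for inhibition of cathepsin S (Homo sapiens) (a lower number here means a stronger inhibitor, a higher number a weaker inhibitor), compound 1 gives 12 nM and compound 2 gives 11 nM; the step of a 1.1-fold lower number from compound 1 to compound 2 (0.04 log units; within the scatter) changes nothing beyond the scatter. Compound 2 thus holds the lower of the two numbers, with compound 1 its nearest neighbour and within the scatter of it, so no order between the two can be read.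

Compound 3 `CC[C@@H](CNc1ccc(OC(F)(F)F)cc1)NC(=O)[C@H](CC1CCCCC1)NC(=O)N1CCOCC1` differs from compound 2 by methyl in place of hydrogen on a saturated chain carbon, two bonds along the chain from an amide-type nitrogen; cut one bond further out, the same change reads methyl to ethyl. Among the measured compounds shown here, none of the measured steps touches this place: the only step available sits at the carbonyl carbon and was within the scatter, so there is no measured precedent for a chain methyl. In this assay the expected step is no change at the digits printed from compound 2 to compound 3 (within the scatter), with no change beyond the scatter foreseen in either direction. Compound 3 is estimated at 11 nM, with a range from 4 nM to 35 nM.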

Compound 3, inhibition constant: 11 nM
For compound 3 middle estimate and measured number coincide at the digits printed; low and high end bracket the measured number.
By their numbers in this assay, from the lowest: compounds 2, 3 and 1 (each within the scatter of the next).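

In this assay, among the compounds shown here, methyl in place of hydrogen gives no change at the digits printed from compound 2 to compound 3 (within the scatter), the first reading on a saturated chain carbon, two bonds along the chain from an amide-type nitrogen; the earlier step sat at the carbonyl carbon and said nothing about this place. Read as methyl to ethyl, the same pair shows that this place takes one more carbon with no change that can be read, though this rests on a single pair with morpholin-4-yl on the carbonyl carbon and sets no trend. No measurement at hand speaks to why the number stays flat here.

Still open, on these data alone, is whether a longer chain such as propyl, a cyclopropyl ring, a hydroxymethyl group, an amine or a carboxylic acid on the same carbon would also stay within the scatter, and so how much room this place has. Also open, as far as these compounds go, is whether methyl in place of hydrogen would read the same with (oxan-4-yl)oxy on the carbonyl carbon, as in compound 1, and what the opposite configuration at the chain carbon would give.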